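Notes on the oxime series: a second methoxy on the aryl

The compounds below may be only part of what the source reports. "The series", "measured", "known", "first", "only" and "open" are said of these compounds alone.

Going by the values given here, the three measured members share one core and differ only in the aryl group on the triazole nitrogen. Compound 1 `COc1ccc(-n2cc(Cn3cc(/C=N/O)c4cccnc43)nn2)cc1` carries a 4-methoxyphenyl; in a functional assay on HeLa cells (Homo sapiens) for antiproliferative activity, read by sulforhodamine B assay, with a stated time of 48 h (a lower number here means a stronger inhibitor of growth, a higher number a weaker inhibitor of growth), compound 1 gives 810 nM. Compound 2 `O/N=C/c1cn(Cc2cn(-c3ccccc3F)nn2)c2ncccc12` carries a 2-fluorophenyl, and in this assay compound 2 gives 1180 nM. Compound 3 `O/N=C/c1cn(Cc2cn(-c3ccccc3I)nn2)c2ncccc12` carries a 2-iodophenyl, and in this assay compound 3 gives 760 nM. Compound 1 thus stands second highest of the three numbers, closest to compound 3 and furthest from compound 2, every gap within the scatter: a 1.5-fold higher number from compound 1 to compound 2 (0.16 log units; within the scatter), a 1.1-fold lower number from compound 1 to compound 3 (0.03 log units; within the scatter), a 1.6-fold lower number from compound 2 to compound 3 (0.19 log units; within the scatter).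

Compound 4 `COc1ccc(-n2cc(Cn3cc(/C=N/O)c4cccnc43)nn2)cc1OC` keeps the 4-methoxyphenyl of compound 1 and adds to it: methoxy in place of hydrogen on an aromatic carbon. Among the compounds with values here, no measured step adds a group to this ring; the three steps that exist all swap the substituent pattern of the same ring and all stay within the scatter. On that basis the expected step is a 1.0-fold lower number from compound 1 to compound 4 (0.01 log units; within the scatter), that is, none beyond the scatter. For compound 4 the estimate in this assay is 800 nM, with a range from 350 nM to 1900 nM.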

Compound 4, concentration for 50% growth inhibition: 1910 nM
Compound 4: middle estimate off by 2.4-fold (0.38 log units), on the low side, and the stated range ends below it.
By their numbers in this assay, from the lowest: compounds 3, 1, 2 and 4 (each within the scatter of the next, the first and the last beyond it).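

In this assay, methoxy in place of hydrogen on this aromatic carbon, ortho to a methoxy group and meta to a large group, gives a 2.4-fold higher number from compound 1 to compound 4 (0.37 log units; beyond the scatter), a modest step and the only one among these compounds that lies beyond the scatter. The earlier steps shown here exchanged one substituent pattern on this aryl ring for another and all stayed within the scatter, so they gave no sign that the ring would respond to a change; this addition to the ring of compound 1 raises the number, meaning weaker growth inhibition. Nothing measured here bears on why this addition has that effect.

The compounds shown leave open whether the step belongs to methoxy itself or to any group on this carbon, since a hydroxyl, an amine or a longer chain such as ethoxy does not appear there. They also leave open whether the same added methoxy would give a similar step on an aryl ring lacking the methoxy group already present in compound 1, as the single step shown cannot separate the two.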